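Swapping the pyridine substituent: from amine to imidazole

The source may hold more compounds than are shown below. What is called first, only, known or untested is meant among the compounds shown, and "the series" means these compounds.

Measured so far:
- compound 1 `CC(C)(C)c1ccc(NC(=O)c2ccc(-c3ncccc3NC3CCCC3)cc2)cc1`: 44 nM
- compound 2 `CN(C)Cc1cccnc1-c1ccc(C(=O)Nc2ccc(C(C)(C)C)cc2)cc1`: 234 nM

In a functional assay for antagonist activity at transient receptor potential cation channel subfamily V member 1 (Rattus norvegicus) (on this read-out lower numbers stand for stronger inhibition and higher numbers for weaker inhibition), compound 2 gives 234 nM, the highest of the two numbers recorded, that is the weaker inhibitor of the pair. Its nearest neighbour is compound 1, and the step of a 5.3-fold higher number from compound 1 to compound 2 (0.73 log units; beyond the scatter) separates them.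

Compound 3 `CC(C)(C)c1ccc(NC(=O)c2ccc(-c3ncccc3-c3ncc[nH]3)cc2)cc1` has not yet been measured. It differs from compound 2 in one place: 1H-imidazol-2-yl in place of (dimethylamino)methyl on an aromatic carbon.

Within the data shown here, the only measured step that touches this position is the one from compound 1 to compound 2, where a 5.3-fold higher number from compound 1 to compound 2 (0.73 log units; beyond the scatter) accompanied the exchange of cyclopentylamino for (dimethylamino)methyl. The new group in compound 3, 1H-imidazol-2-yl, brings back a hydrogen-bond donor, as cyclopentylamino had, but within a five-membered aromatic ring rather than an open chain. Among the measured compounds shown here, no measured step shows an aromatic ring at this position, so the comparison is indirect. The expectation is that compound 3 moves back toward compound 1, giving a 2.3-fold lower number from compound 2 to compound 3 (0.37 log units; beyond the scatter) in this assay. The estimated value for compound 3 is 100 nM, with a range of 25 nM to 400 nM.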

Compound 3, half-maximal inhibitory concentration: 694 nM
For compound 3 the middle estimate is 6.9-fold (0.84 log units) below the measured one; measured number above the stated range.
By their numbers in this assay, from the lowest: compound 1; then compound 2; then compound 3.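

In this assay the exchange of (dimethylamino)methyl for 1H-imidazol-2-yl on this aromatic carbon raises the number (from a 3.0-fold higher number from compound 2 to compound 3 (0.47 log units; beyond the scatter)), even though the entering group carries a hydrogen-bond donor and the leaving group carries none. Set against the cyclopentylamino group of the first compound, the same ring gives the largest step seen at this position so far (from a 16-fold higher number from compound 1 to compound 3 (1.20 log units; beyond the scatter)), so at least for this pair, adding a donor on this carbon does not recover the stronger inhibition of compound 1. No measurement is available to explain why compound 3 is the weakest of the three inhibitors.

With only three groups at this position, the compounds shown cannot separate the effect of having an aromatic ring on this carbon from the effect of this particular ring and its ring hydrogen. A plain phenyl group, a 1-methylimidazol-2-yl group or a smaller open amine such as methylamino would each test a different part of that question.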